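The source may hold more compounds than are shown below. What is called first, only, known or untested is meant among the compounds shown, and "the series" means these compounds.

Measured so far:
compound 1 `CCOC(=O)C1=C(Nc2ccccc2)S/C(=C\c2ccc(Br)c(O)c2)C1=O` — 39.8%
compound 2 `CCOC(=O)C1=C(Nc2ccccc2)S/C(=C\c2ccc[nH]2)C1=O` — 49.2%

In a functional assay on JAR cells (Homo sapiens) for inhibition, read by MTT assay, with a stated time of 72 h, tested at 10 uM (on this read-out higher numbers stand for more inhibition at the one concentration tested (going by the name of the read-out) and lower numbers for less inhibition), compound 1 gives 39.8% and compound 2 gives 49.2%. Among the compounds with values here, compound 2 holds the higher of the two numbers, but the only measured step, a number 9.4 percentage points higher from compound 1 to compound 2 (within the scatter), lies within the scatter, so the two compounds cannot be ordered on this read-out.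

Compound 3 `CCOC(=O)C1=C(Nc2ccc(OC)cc2)S/C(=C\c2ccc[nH]2)C1=O` has not yet been measured in this assay. It differs from compound 2 by methoxy in place of hydrogen on an aromatic carbon, the change read one bond further out being phenyl to 4-methoxyphenyl. Within the data shown here, no measured step bears on this change: the single step between compound 1 and compound 2 alters the group on the double-bonded chain carbon, not the aromatic ring of the anilino part, and it was itself within the scatter. There is therefore nothing in the series that points to a step beyond the scatter in this assay in either direction, and the expectation for compound 3 is a number close to that of compound 2, with the step of a number 1.2 percentage points lower from compound 2 to compound 3 (within the scatter) estimated to stay within the scatter.

Compound 3 is thus expected to give about 48% in this assay, with a range from 33% to 63%.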

Compound 3, a percentage reported as inhibition, at one concentration (the size of the read-out at that concentration, not a potency): 27.6%
Estimate against measurement, compound 3: 20.4 percentage points above; the whole stated range lies above it.
By their numbers in this assay, from the lowest: compound 3; then compounds 1 and 2 (each within the scatter of the next).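

In this assay, methoxy in place of hydrogen on an aromatic carbon, para to a large group, gives a number 21.6 percentage points lower from compound 2 to compound 3 (beyond the scatter). Within the data shown here, this is the first step that clears the scatter, and the first reading on the phenyl group of the anilino part, so this position is not indifferent to substitution in this read-out. The only earlier step, a number 9.4 percentage points higher from compound 1 to compound 2 (within the scatter), changed the group on the double-bonded chain carbon and gave no readable difference, so among the compounds shown the phenyl to 4-methoxyphenyl change is the only one that separates two compounds, and no measurement at hand accounts for that step.

From the compounds shown here alone, whether the step belongs to methoxy itself or to any group at this place stays open; a fluorine, a hydroxy group or an amine on the same carbon would begin to separate the two readings. Going by these compounds, it is also open whether the same change carries over when the 4-bromo-3-hydroxyphenyl group of compound 1 replaces the pyrrole of compound 2, and whether the step holds at concentrations other than the single one tested.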